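Compound 2 and the Step to Compound 3

The source may report more compounds than this note shows. Statements on the series, on what has been measured and on what is new or still open speak of the compounds shown alone.

In a functional assay on cells (Neutrophil, Homo sapiens), with a stated time of 5 min (a higher number here means a weaker inhibitor, a lower number a stronger inhibitor), compound 1 `COc1cc([C@H]2Oc3c(OC)cc(/C=C/C=O)cc3[C@@H]2CO)cc(OC)c1O` gives 19300 nM and compound 2 `CC(C)(O)[C@H](O)COc1ccc(/C=C/CO)cc1` gives 32600 nM so the two stand level within the usual scatter. Compound 3 `CC(C)=CCOc1ccc(/C=C/CO)cc1` carries 2-methylprop-1-en-1-yl in place of 1,2-dihydroxy-2-methylpropyl on a saturated chain carbon bound to an oxygen on an aromatic ring, a change counted as 2-methylprop-1-en-1-yl in place of 1,2-dihydroxy-2-methylpropyl on a saturated chain carbon bound to an oxygen on an aromatic ring in full. For the measured compounds named here, no measured pair shows such a change, so in this assay only a modest move toward a lower number is expected. The expected step is a 2.2-fold lower number from compound 2 to compound 3 (0.34 log units; beyond the scatter) as an estimate only. For compound 3 the estimated value is 15000 nM with a range from 5000 nM to 40000 nM as the expected span.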

Compound 3, half-maximal inhibitory concentration: 9640 nM
Beside the measured number, compound 3's estimate is 1.6-fold (0.19 log units) above it, within the range that was stated.
By their numbers in this assay, from the lowest: compounds 3, 1 and 2 (each within the scatter of the next, the first and the last beyond it).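

In this assay, for the compounds shown here, the exchange of 1,2-dihydroxy-2-methylpropyl for 2-methylprop-1-en-1-yl on a saturated chain carbon bound to an oxygen on an aromatic ring gives a 3.4-fold lower number from compound 2 to compound 3 (0.53 log units; beyond the scatter), the first step at this position that can be read. It shows that the number here responds to this group, and that it falls when a group without hydrogen-bond donors or acceptors enters. No measurement shown explains the step.

The exchange removes both hydroxyl groups and the stereocentre and adds the double bond at once, so their shares stay unresolved. As far as these compounds go, how a single hydroxyl, a saturated 2-methylpropyl, an amine or a carboxylic acid at this place would behave remains open.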